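Swapping a thiadiazole for a triazole on the sulfur

This account rests on a few compounds, and the source may have more. Where it says the series, first, only, none or still open, it means among the compounds named here.

Four related compounds share a common core and differ mainly in the small aromatic ring carried on a sulfur attached to a saturated chain carbon, and in the group on the outer benzene ring. Compound 1 `Cc1ccc(-c2cs/c(=N/NC(=O)CSc3nnnn3-c3ccccc3)n2-c2ccccc2)cc1` and compound 2 `O=C(CSc1ncccn1)N/N=c1/scc(-c2ccc(Br)cc2)n1-c1ccccc1` have been tested in a functional assay on C6 cells (Rattus norvegicus) for cytotoxicity, read by MTT assay, with a stated time of 24 h; on this read-out higher numbers stand for weaker inhibition and lower numbers for stronger inhibition. In this assay compound 1 gives 14.7 ug/mL. For compound 2 this assay reports only a limit, > 200 ug/mL, which is a boundary of what the assay could read and not a number. Among the measured compounds shown here, that limit is the one value of the set sitting at the limit of > 200 ug/mL in this assay, at which 1 of the 3 values shown sits. From the compounds shown here alone, compound 3 `Cc1nnc(SCC(=O)N/N=c2/scc(-c3ccc(C#N)cc3)n2-c2ccccc2)s1` stands apart: in this assay compound 3 is recorded as "not determined" (no result reported), so it has no number to compare with the other two, and its place on the scale is unknown.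

Compound 4 `Cn1cnnc1SCC(=O)N/N=c1/scc(-c2ccc(C#N)cc2)n1-c1ccccc1` follows from compound 3 by a single change (4-methyl-4H-1,2,4-triazol-3-yl in place of 5-methyl-1,3,4-thiadiazol-2-yl on a sulfur). For the measured compounds named here, because compound 3 has no measured value, no step can be stated between them, and the expectation for compound 4 must rest on the spread seen between compound 1 and compound 2. With one value read as a number and one as a limit, the expected outcome for compound 4 is a moderate value, estimated at 60 ug/mL, within a range from 15 ug/mL to 200 ug/mL.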

Compound 4, half-maximal inhibitory concentration: > 200 ug/mL
Compound 4 gave a limit, no number; the forecaster's own chance of this, stated with the estimate: 35%; middle value at least 3.3-fold (0.52 log units) away from the limit.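

In this assay, among the compounds shown here, compound 3 is recorded without a numerical result, so no step from it to compound 4 can be read. Compound 4 gives only a limit, not a number, and it shares that limit with another compound: the limit of > 200 ug/mL in this assay, at which 2 of the 4 values shown sit. The compounds shown leave open whether 4-methyl-4H-1,2,4-triazol-3-yl in place of 5-methyl-1,3,4-thiadiazol-2-yl changes the read-out at all.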